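The source may report more compounds than this note shows. Statements on the series, on what has been measured and on what is new or still open speak of the compounds shown alone.

In a functional assay on A549 cells (Homo sapiens) for cytotoxicity, read by MTT assay, with a stated time of 72 h (a higher number here means a weaker inhibitor, a lower number a stronger inhibitor), compound 1 `CC(C)(C)C1=CC(=O)C=C(NCCC(=O)O)C1=O` gives 171000 nM and compound 2 `CC1=CCC[C@H]2[C@](C)(CC3=CC(=O)C(N4CCC[C@H]4C(=O)O)=CC3=O)[C@@H](C)CC[C@]12C` gives 49200 nM as its reading. Compound 3 `CC1=CCC[C@H]2[C@](C)(CC3=CC(=O)C=C(N[C@@H](CC(C)C)C(=O)O)C3=O)[C@@H](C)CC[C@]12C` comes in at 19700 nM and so holds the lowest number of the three, which makes it the strongest inhibitor measured so far, with its gaps to both of the others beyond the scatter.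

Compound 4 `CC1=CCC[C@H]2[C@](C)(CC3=CC(=O)C=C(N[C@@H](C(=O)O)C(C)C)C3=O)[C@@H](C)CC[C@]12C` has not yet been measured. Its structure departs from that of compound 3 at a single place, and the change is 1-carboxy-2-methylpropyl in place of 1-carboxy-3-methylbutyl on an amine nitrogen in the account of what leaves and enters. In words, 1-carboxy-2-methylpropyl stands in place of 1-carboxy-3-methylbutyl on an amine nitrogen.

Among the measured compounds shown here, no measured pair of compounds differs by one change alone, so the data offer no direct precedent for this swap. The expectation therefore rests on compound 3 at 19700 nM as the nearest measured structure. The estimated step of a 1.3-fold higher number from compound 3 to compound 4 (0.12 log units; within the scatter) is expected to stay within the scatter, with only a slight lean toward a higher number. For compound 4 the estimated value is 26000 nM with an expected range from 12000 nM to 55000 nM in this cell test.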

Compound 4, half-maximal inhibitory concentration: 23800 nM
Compound 4: the middle estimate sits 1.1-fold (0.04 log units) above what was measured, within the range that was stated.
By their numbers in this assay, from the lowest: compounds 3 and 4 (each within the scatter of the next); then compound 2; then compound 1.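

In this assay, among the compounds shown here, replacing 1-carboxy-3-methylbutyl with 1-carboxy-2-methylpropyl on an amine nitrogen gives a 1.2-fold higher number from compound 3 to compound 4 (0.08 log units; within the scatter), and this pair supplies the only direct reading at this position, since none of the other compounds differ from each other in one place alone. For the compounds shown here, on the shared core, the side chain at this nitrogen can therefore be exchanged for one with fewer heavy atoms, keeping its carboxyl group and a defined stereocentre, without the reading moving beyond the scatter, although one pair describes only this one change and sets no trend. Nothing available here gives a reason for this result or ties it to a measured property of either group.

On these data alone, it remains open whether a group of another kind at this nitrogen, such as a benzyl group, a longer chain or a side chain carrying an amine, would also leave the reading within the scatter. Also open, as far as these compounds go, is whether the carboxylic acid can give way to an amide or a methyl ester, and whether the opposite configuration at the stereocentre would change the number.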